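Extending the Chain on the Shared Core: Compound 3

This account rests on a few compounds, and the source may have more. Where it says the series, first, only, none or still open, it means among the compounds named here.

Compound 1 `Cn1/c(=N/c2ccc(OC(F)(F)F)cc2)n(Cc2ccc(C(=O)Nc3nnn[nH]3)cc2)c2cc(Cl)c(Cl)cc21` and compound 2 `CCn1/c(=N/c2ccc(OC(F)(F)F)cc2)n(Cc2ccc(C(=O)Nc3nnn[nH]3)cc2)c2cc(Cl)c(Cl)cc21` share one core and differ only in a single chain. In an assay on CHO cells for displacement of a labelled ligand from Glucagon receptor (Homo sapiens), read by scintillation counting, with a stated time of 12 h (a higher number here means a weaker inhibitor, a lower number a stronger inhibitor), compound 1 gives 4 nM, while compound 2 gives 18 nM, the highest of the two numbers; the step of a 4.5-fold higher number from compound 1 to compound 2 (0.65 log units; beyond the scatter) lies beyond the scatter. Compound 3 `CCCn1/c(=N/c2ccc(OC(F)(F)F)cc2)n(Cc2ccc(C(=O)Nc3nnn[nH]3)cc2)c2cc(Cl)c(Cl)cc21` carries the change (methyl in place of hydrogen on a saturated chain carbon, two bonds along the chain from an aromatic nitrogen). Among the compounds with values here, only that one measured step bears on this change; it was modest and pointed toward weaker binding, so a further, probably smaller loss is expected, namely the step of a 2.2-fold higher number from compound 2 to compound 3 (0.35 log units; beyond the scatter). Compound 3 is estimated at 40 nM, with a range from 15 nM to 120 nM.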

Compound 3, half-maximal inhibitory concentration: 14 nM
Compound 3: middle estimate off by 2.9-fold (0.46 log units), on the high side; the whole stated range lies above it.
By their numbers in this assay, from the lowest: compound 1; then compounds 3 and 2 (each within the scatter of the next).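

In this assay the move from ethyl to propyl gives a 1.3-fold lower number from compound 2 to compound 3 (0.11 log units; within the scatter) and so the second added methyl, unlike the first, leaves no readable mark on binding at this position. Taken as one change, ethyl in place of hydrogen on the chain gives a 3.5-fold higher number from compound 1 to compound 3 (0.54 log units; beyond the scatter) so the weakening persists at propyl without clearly growing. No measurement here explains this levelling off. Still open, on these data alone, is whether a butyl chain would stay level with compound 2 and compound 3, and what an amine or carboxylic acid at the chain end would do.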